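The source may report more compounds than this note shows. Statements on the series, on what has been measured and on what is new or still open speak of the compounds shown alone.

Compound 2 `CC(C)(C)C(=O)N(CCCCCCN1C[C@H](O)[C@@H](O)[C@H](O)[C@H]1CO)C1CCCCC1` stands at a limit in an ADME assay on BHK cells (Mesocricetus auratus) for cytotoxicity, read by MTT assay (on this read-out higher numbers stand for lower toxicity in this test and lower numbers for higher toxicity in this test), where it gives > 500000 nM. Its close relative compound 1 `CC1CCCCC1N(CCCCCCN1C[C@H](O)[C@@H](O)[C@H](O)[C@H]1CO)C(=O)C(C)(C)C` likewise gives only a limit in this assay, namely > 500000 nM. The step that the two limits leave unreadable from compound 1 to compound 2 is therefore not readable, and the limit of > 500000 nM in this assay, at which 2 of the 2 values shown sit, holds both values. Compound 3 `CC(C)(C)C(=O)N(CCCCCCN1C[C@H](O)[C@@H](O)[C@H](O)[C@H]1CO)c1ccc(F)cc1F` differs from compound 2 by 2,4-difluorophenyl in place of cyclohexyl on an amide-type nitrogen. Among the measured compounds shown here, no measured step bears on this exchange; the only step available stays hidden behind the limit, so the expectation for compound 3 can rest only on where compound 2 stands. Compound 3 is therefore expected to sit near the same limit in this assay, with an estimated step of a number no higher from compound 2 to compound 3 (the limit leaves the size open). The estimate for compound 3 in this assay is 500000 nM, within 200000 nM to 1000000 nM, and a reading that again comes back as a limit is considered the likeliest outcome.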

Compound 3, half-maximal cytotoxic concentration: > 500000 nM
Compound 3: only a limit was reported; the forecaster's own chance of this, stated with the estimate: 70%; the middle value lies on the limit itself.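

Among the compounds shown here, compound 3 gives > 500000 nM in this assay, which is a limit, so no step among compound 1, compound 2 and compound 3 can be read: the limit of > 500000 nM in this assay, at which 3 of the 3 values shown sit. Going by these compounds, whether cyclohexyl, 2-methylcyclohexyl and 2,4-difluorophenyl differ at all in this assay stays open.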